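The source may report more compounds than this note shows. Statements on the series, on what has been measured and on what is new or still open speak of the compounds shown alone.

Measured so far in an ADME assay on HEK293 cells (Homo sapiens) for antiproliferative activity, read by MTT assay, with a stated time of 24 h; on this read-out higher numbers stand for weaker inhibition and lower numbers for stronger inhibition:
Compound 1, `COc1ccc(/C=C/C(=O)c2cc(-c3cc(OC)c(OC)c(OC)c3)n3nc(-c4ccccc4)cc3n2)cc1OC`: compound 1 gives 41000 nM
Compound 2, `COc1ccc(-c2cc(/C=C/C(=O)c3ccccc3)nc3cc(-c4ccccc4)nn23)cc1`: compound 2 gives 53200 nM
Compound 3, `COc1ccc(/C=C/C(=O)c2cc(-c3cc(OC)c(OC)c(OC)c3)n3nc(-c4ccccc4)cc3n2)cc1`: compound 3 gives 46600 nM

All three numbers lie close together. Compound 3 and compound 1 differ in one place, (methoxy in place of hydrogen on an aromatic carbon), and the step is a 1.1-fold lower number from compound 3 to compound 1 (0.06 log units; within the scatter). Compound 2 and compound 3 share the same kind of change in their side groups, but the difference between the two cores is not broken down here. Compound 4, `COc1ccc(-c2cc(/C=C/C(=O)c3ccccc3)nc3cc(-c4ccccc4)nn23)cc1OC`, is not yet measured; it differs from compound 2 by methoxy in place of hydrogen on an aromatic carbon, the same change as from compound 3 to compound 1. Because the earlier step was a 1.1-fold lower number from compound 3 to compound 1 (0.06 log units; within the scatter), the step of a 1.1-fold lower number from compound 2 to compound 4 (0.04 log units; within the scatter) is expected to be of the same small size. Compound 4 is thus estimated at 48000 nM, with a range from 25000 nM to 90000 nM.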

Compound 4, half-maximal inhibitory concentration: 51200 nM
The estimate for compound 4 lay 1.1-fold (0.03 log units) below the measured number; the range from low to high includes it.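

In this assay the added methoxy gives a 1.0-fold lower number from compound 2 to compound 4 (0.02 log units; within the scatter), a step too small to read as an effect on this core. The two cores agree on this change: the same change on two cores in this assay, a 1.1-fold lower number (0.06 log units; within the scatter) from compound 3 to compound 1 and a 1.0-fold lower number (0.02 log units; within the scatter) from compound 2 to compound 4, 1.1-fold (0.04 log units) apart, within the scatter of two such steps. Both steps lie within the scatter, so the agreement is between two near-null steps and does not show that a larger effect would carry from one core to the other.

The compounds shown leave open whether an amine or a carboxylic acid in place of this methoxy would move the number on either core. They also leave open whether such a step, if it exceeded the scatter, would match between the two cores.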